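The compounds below may be only part of what the source reports. "The series", "measured", "known", "first", "only" and "open" are said of these compounds alone.

Series notes, measured in an ADME assay on microsomes from liver (Mus musculus) for metabolic stability, read by HPLC, with a stated time of 4 h; a higher number here means faster removal of the compound, a lower number slower removal:

- compound 1 `CN(C)c1ccc2cc(-c3ccc(Cl)cc3)c(N)nc2c1`: 290 mL/min/kg
- compound 2 `CN(C)c1ccc2cc(-c3cn(C)c4ccccc34)c(N)nc2c1`: 210 mL/min/kg
- compound 3 `CN(C)c1ccc2cc(-c3nc4ccccc4s3)c(N)nc2c1`: 280 mL/min/kg

Compound 2, at 210 mL/min/kg, lies within the scatter of both compound 1 and compound 3, so the three values cannot be ranked in this assay. These three compounds carry different groups on the shared core, yet their values stay close together.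

The next compound is compound 4 `Cn1cc(-c2cc3ccc(N4CCCCC4)cc3nc2N)c2ccccc21`, which has piperidin-1-yl in place of dimethylamino on an aromatic carbon. Among the measured compounds shown here, all three measured compounds carry dimethylamino, and no measured pair differs in one place only. The series therefore gives no direct measure of this replacement. The closest guide is compound 2 itself, at 210 mL/min/kg, and the narrow spread across compound 1, compound 2 and compound 3 gives no reason to expect a large move in either direction.

No step beyond the scatter is expected, and no direction is predicted with confidence. The estimated step is a 1.1-fold higher number from compound 2 to compound 4 (0.04 log units; within the scatter). For compound 4 the expected value is 230 mL/min/kg, with an estimated range of 120 mL/min/kg to 400 mL/min/kg.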

Compound 4, clearance: 95 mL/min/kg
For compound 4 the middle estimate is 2.4-fold (0.38 log units) above the measured one, and the stated range ends above it.
By their numbers in this assay, from the lowest: compound 4; then compounds 2, 3 and 1 (each within the scatter of the next).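

In this assay, the aromatic carbon that carries dimethylamino proves to be a place where a single change can be read: piperidin-1-yl in place of dimethylamino gives a 2.2-fold lower number from compound 2 to compound 4 (0.34 log units; beyond the scatter). Compounds 1, 2 and 3 share dimethylamino and differ elsewhere on the shared core, so they could not show this; the step now gives one modest, beyond-the-scatter change at this position, resting on a single pair. No measurement shown bears on why the number falls with this replacement.

From the compounds shown here alone, it remains open whether the same replacement gives a like step with the other groups carried by compound 1 and compound 3. Going by these compounds, it is also open whether the step follows the ring itself or the added heavy atoms, a question that pyrrolidin-1-yl, morpholin-4-yl or diethylamino at this same aromatic carbon would help to separate.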